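Swapping Nitro for Methyl on the Aromatic Ring

The source may hold more compounds than are shown below. What is called first, only, known or untested is meant among the compounds shown, and "the series" means these compounds.

Three close relatives share one core and differ only in the aromatic ring on the amine nitrogen. In a functional assay, with a stated time of 6 min (on this read-out lower numbers stand for stronger inhibition and higher numbers for weaker inhibition), compound 1 `Fc1ccc(NCn2nc(-c3ccc4c(c3)OCCO4)oc2=S)cc1` gives 6480 nM, compound 2 `S=c1oc(-c2ccc3c(c2)OCCO3)nn1CNc1cccc(Br)c1` gives 10800 nM and compound 3 `O=[N+]([O-])c1ccc(NCn2nc(-c3ccc4c(c3)OCCO4)oc2=S)cc1` gives 9950 nM. Compound 3 therefore lies within the scatter of both relatives, so the three numbers cannot be ranked.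

The next compound, compound 4 `Cc1ccc(NCn2nc(-c3ccc4c(c3)OCCO4)oc2=S)cc1`, has methyl in place of nitro on an aromatic carbon, para to a large group: methyl in place of nitro on an aromatic carbon. For the measured compounds named here, no measured step makes this exact swap. The closest, nitro in place of fluoro on an aromatic carbon, is a 1.5-fold higher number from compound 1 to compound 3 (0.19 log units; within the scatter). The other two steps are a 1.7-fold higher number from compound 1 to compound 2 (0.22 log units; within the scatter) and a 1.1-fold lower number from compound 2 to compound 3 (0.04 log units; within the scatter). None of these three steps leaves the scatter, so no step beyond the scatter is expected in this assay. The expected step is a 1.2-fold lower number from compound 3 to compound 4 (0.07 log units; within the scatter). For compound 4 the estimated value is 8500 nM, with an expected range from 4500 nM to 16000 nM.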

Compound 4, half-maximal inhibitory concentration: 5700 nM
Beside the measured number, compound 4's estimate is 1.5-fold (0.17 log units) above it; the measured number falls inside the stated range.
By their numbers in this assay, from the lowest: compounds 4, 1, 3 and 2 (each within the scatter of the next).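

In this assay, putting methyl in place of nitro on this aromatic carbon, para to a large group, gives a 1.7-fold lower number from compound 3 to compound 4 (0.24 log units; within the scatter) and so stays inside the usual scatter, even though the entering group has fewer heavy atoms and no hydrogen-bond acceptors. The other two new comparisons also stay inside the scatter: methyl in place of fluoro gives a 1.1-fold lower number from compound 1 to compound 4 (0.06 log units; within the scatter) and 4-methylphenyl in place of 3-bromophenyl gives a 1.9-fold lower number from compound 2 to compound 4 (0.28 log units; within the scatter) in this series. Fluoro, nitro and methyl therefore cannot be told apart on this read-out, and no separate measurement is available to interpret that result.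

From the compounds shown here alone, whether an amine or a carboxylic acid on this carbon would produce a step beyond the scatter remains open. The same question stands for a longer chain in place of methyl.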